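This account rests on a few compounds, and the source may have more. Where it says the series, first, only, none or still open, it means among the compounds named here.

In a physicochemical assay for solubility (on this read-out lower numbers stand for lower solubility and higher numbers for higher solubility), compound 1 `O=C(O)c1ccc(C(=O)/C(=C\c2ccc(F)c([N+](=O)[O-])c2)Sc2ccc(Br)cc2)cc1` gives < 1000 ug/mL as a limit of the assay, not a number. Compound 2 `O=C(O)c1ccc(C(=O)/C(=C\c2ccc(F)c([N+](=O)[O-])c2)SCc2ccc(Cl)cc2)cc1` gives < 1000 ug/mL and this too is only a limit, so it has no exact place on the scale. Within the data shown here, the sole measured step is a step that the two limits leave unreadable from compound 1 to compound 2, with 4-chlorobenzyl in place of 4-bromophenyl on a sulfur. All the evidence so far is the limit of < 1000 ug/mL in this assay, at which 2 of the 2 values shown sit. Compound 3 `Cc1ccc(CS/C(=C/c2ccc(F)c([N+](=O)[O-])c2)C(=O)c2ccc(C(=O)O)cc2)cc1` carries methyl in place of chloro on an aromatic carbon, para to a large group: methyl in place of chloro on an aromatic carbon. Among the measured compounds shown here, no measured step covers this swap, and the one step available has no readable size, so no direction can be drawn for this assay and nothing beyond the scatter is expected. The expected step is a step that the limit leaves unreadable from compound 2 to compound 3. The estimated solubility of compound 3 is 700 ug/mL, with an expected range from 150 ug/mL to 1000 ug/mL, and the assay may well report only a limit again.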

Compound 3, solubility: < 1000 ug/mL
Compound 3: a limit, no number (the forecaster's own chance of this, stated with the estimate: 90%); the middle value lies beyond the limit too.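

Compound 3 also gives only a limit, not a number, so its steps from compound 1 and compound 2 cannot be read in this assay. The compounds shown leave open where each one truly sits on the scale and whether any of these swaps shifts the read-out.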